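Side-chain shortening at the limit of the toxicity read-out

The source may report more compounds than this note shows. Statements on the series, on what has been measured and on what is new or still open speak of the compounds shown alone.

In a functional assay on HEL cells (Homo sapiens) (on this read-out higher numbers stand for lower toxicity in this test and lower numbers for higher toxicity in this test), compound 1 `CCCCCCCCCCCc1cc2cn(COCCO)c(=O)nc2o1` gives 132000 nM as a measured number. Compound 2 `CCCCCCCCCCc1cc2cn(COCCO)c(=O)nc2o1` gives > 200000 nM here, which is a limit of the assay and not a number. Compound 3 `CCCCCCCCc1cc2cn(COCCO)c(=O)nc2o1` differs from compound 2 by hydrogen in place of ethyl on a saturated chain carbon, eight bonds along the chain from an aromatic carbon with hydrogen in place of ethyl. Going by the values given here, the only measured guide is an at least 1.5-fold higher number from compound 1 to compound 2 (0.18 log units; that floor lies within the scatter) on this chain, and readings may again meet the limit of > 200000 nM in this assay, at which 1 of the 2 values shown sits. On that guide the expected step is a step that the limit leaves unreadable from compound 2 to compound 3 in the same upward direction and no larger than the scatter. For compound 3 the estimate is 250000 nM with an expected range of 150000 nM to 500000 nM for the measurement.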

Compound 3, half-maximal cytotoxic concentration: > 200000 nM
Compound 3 was reported as a limit; the forecaster's own chance of this, stated with the estimate: 75%; the middle value does not contradict the limit.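

In this assay compound 3 gives > 200000 nM, which is a limit of the assay and not a number. Going by these compounds alone, replacing ethyl with hydrogen on a saturated chain carbon, eight bonds along the chain from an aromatic carbon, gives a step from the limit of compound 2 that cannot be read; the only readable comparison is an at least 1.5-fold higher number from compound 1 to compound 3 (0.18 log units; that floor lies within the scatter). The series therefore gains a second reading at the limit and no graded trend with chain length: the limit of > 200000 nM in this assay, at which 2 of the 3 values shown sit.

Going by these compounds, what a chain longer than that of compound 1, or an amine in place of the chain, would read in this assay stays open.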